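Cytotoxicity notes on amide variants of the shared core

A few compounds are considered here, and "the series" means these few. Any claim that something is new, unique, unknown or untested is made for them only; others in the source may bear on it.

The series shares one core; compound 2 is `CNC(=O)c1c(NO)cc(-c2ccc(F)cc2)oc1=O`, compound 1 is `Cc1ccc(NC(=O)c2c(NO)cc(-c3ccc(F)cc3)oc2=O)cc1` and compound 3 is `CNC(=O)c1c(NO)cc(-c2ccc(C)cc2)oc1=O`. In an ADME assay on Huh-7 cells (Homo sapiens) for cytotoxicity, read by a luciferase reporter and WST assay, with a stated time of 3 days (a lower number here means that less compound is tolerated, a higher number that more compound is tolerated), compound 2 gives > 20000 nM, which is a limit of the assay and not a number. Compound 1 gives > 20000 nM in this assay, again a limit. Compound 3 gives > 20000 nM in this assay, also a limit. Compound 2 thus stands at the limit of > 20000 nM in this assay, at which 3 of the 3 values shown sit, with no number of its own. The step that the two limits leave unreadable from compound 1 to compound 2 and the step that the two limits leave unreadable from compound 2 to compound 3 are both unreadable.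

Compound 4 is `O=C(NCCO)c1c(NO)cc(-c2ccc(F)cc2)oc1=O`. It differs from compound 2 by hydroxymethyl in place of hydrogen on a saturated chain carbon bound to an amide-type nitrogen. Of the measured steps, the step from compound 1 to compound 2 is the one that also alters the group on the amide-type nitrogen, and it could not be sized; the step from compound 2 to compound 3 alters the group on the aromatic carbon and bears less on this change. Among the compounds with values here, no measured step gives a size for the change, so no step beyond the scatter is expected in this assay in either direction. The expected step from compound 2 to compound 4 is a step that the limit leaves unreadable from compound 2 to compound 4, and it is expected to stay unreadable. Compound 4 is therefore estimated at 30000 nM in this assay, with a range of 10000 nM to 100000 nM, most likely reported as a limit once more.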

Compound 4, half-maximal cytotoxic concentration: > 20000 nM
Compound 4: a limit, no number (the forecaster's own chance of this, stated with the estimate: 85%); the middle value is on the limit's open side.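

Compound 4 gives > 20000 nM in this assay, which is a limit of the assay and not a number. Within the data shown here, the steps to compound 4 from compound 1 and from compound 2 therefore cannot be read, and no new step follows: the limit of > 20000 nM in this assay, at which 4 of the 4 values shown sit. The compounds shown leave open at what concentration any of them becomes cytotoxic, and whether changing the group on the amide-type nitrogen alters tolerance at all.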